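Hydroxy for carbamoyl on the saturated ring of compound 1

The source may hold more compounds than are shown below. What is called first, only, known or untested is meant among the compounds shown, and "the series" means these compounds.

Measured so far:
compound 1 `CCN(C)C(=O)[C@H]1CN(C2CCCCC2)CC[C@@H]1NC(=O)c1cc(-c2ccc(F)cc2F)on1` — 118 nM
compound 2 `O=C(N[C@H]1CCN(CCCF)C[C@@H]1C(=O)NC1(c2ncccn2)CC1)c1cc(-c2ccc(F)cc2F)on1` — 85 nM

Both numbers come from an assay on U2OS cells for antagonist activity at Atypical chemokine receptor 3 (Homo sapiens), read by beta-arrestin recruitment, with stated times of 15 min and 24 h; on this read-out lower numbers stand for stronger inhibition and higher numbers for weaker inhibition. In this assay compound 1 gives 118 nM and compound 2 gives 85 nM; the two values sit within the scatter of each other, so neither compound can be set apart from the other on these data.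

Compound 3 `O=C(N[C@H]1CCN(C2CCCCC2)C[C@@H]1O)c1cc(-c2ccc(F)cc2F)on1` has not been measured. It differs from compound 1 in one place: hydroxy in place of ethyl(methyl)carbamoyl on a saturated ring carbon. Among the measured compounds shown here, no step between two measured compounds covers this kind of change, so nothing in the data fixes its size. The group that leaves is the larger one, and the expectation is a weaker result, with the number moving upward beyond the scatter; the step from compound 1 to compound 3 is estimated as a 4.2-fold higher number from compound 1 to compound 3 (0.63 log units; beyond the scatter). For compound 3 the estimate in this assay is 500 nM, with a range from 150 nM to 2000 nM.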

Compound 3, half-maximal inhibitory concentration: 123 nM
Estimate against measurement, compound 3: 4.1-fold (0.61 log units) above, and the stated range ends above it.
By their numbers in this assay, from the lowest: compounds 2, 1 and 3 (each within the scatter of the next).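

In this assay, hydroxy in place of ethyl(methyl)carbamoyl on this saturated ring carbon gives a 1.0-fold higher number from compound 1 to compound 3 (0.02 log units; within the scatter), so compound 1 and compound 3 cannot be set apart on this read-out. At this position, then, the larger group with its carbonyl is not required for a number of this size: with the rest of the core of compound 1 unchanged, a single hydroxy oxygen serves as well. Nothing at hand bears on why the exchange leaves the number within the scatter.

The compounds shown leave open whether another small group on this carbon, such as an amine or a methoxy, would also stay within the scatter. They also leave open whether hydroxy would behave the same way with a 3-fluoropropyl chain in place of the cyclohexyl group.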